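This account rests on a few compounds, and the source may have more. Where it says the series, first, only, none or still open, it means among the compounds named here.

Going by the values given here, compound 2 `CN(C)c1ccc(-c2cccc(NC(=O)Oc3ccccc3)c2)cc1` gives the higher of the two numbers so far in an assay on COS-7 cells for inhibition of patatin-like phospholipase domain-containing protein 2 (Mus musculus) (a higher number here means a weaker inhibitor, a lower number a stronger inhibitor), with compound 2 at 73000 nM. Among the compounds with values here, compound 1 `CC(C)COC(=O)Nc1cccc(-c2ccc(N(C)C)cc2)c1` gives 22000 nM; the one measured step, a 3.3-fold higher number from compound 1 to compound 2 (0.52 log units; beyond the scatter), is the only one bearing on the next change. Compound 3 `CN(C)c1ccc(-c2cccc(NC(=O)OCc3ccccc3)c2)cc1` carries benzyl in place of phenyl on an oxygen next to a carbonyl group. As the benzyl carbamate again places a saturated carbon on the carbonyl oxygen, as in compound 1, a modest move back toward compound 1 is expected, giving a 2.1-fold lower number from compound 2 to compound 3 (0.32 log units; beyond the scatter). Compound 3 is therefore estimated at 35000 nM in this assay, with a range from 12000 nM to 100000 nM.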

Compound 3, half-maximal inhibitory concentration: > 200000 nM
Compound 3: no number, only a limit; the forecaster's own chance of this, stated with the estimate: 15%; at least 5.7-fold (0.75 log units) between middle value and limit.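

Compound 3 gives no number in this assay, only a limit: the limit of > 200000 nM in this assay, at which 1 of the 3 values shown sits. This position tolerates neither phenyl nor benzyl equally, with an at least 2.7-fold higher number from compound 2 to compound 3 (0.43 log units; beyond the scatter), so the change on the oxygen is not neutral even though it adds a single carbon. The saturated carbon shared by compound 1 and compound 3 does not alone preserve the number of compound 1, with an at least 9.0-fold higher number from compound 1 to compound 3 (0.95 log units; beyond the scatter).

As far as these compounds go, the true size of both steps remains unknown. Also open, from the compounds shown here alone, is whether a cyclohexylmethyl group or a longer alkyl chain on this oxygen would stay near compound 1.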